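Tolerated dose after losing the methoxy group of compound 2

The source may hold more compounds than are shown below. What is called first, only, known or untested is meant among the compounds shown, and "the series" means these compounds.

- Compound 1 `C=C1CC[C@@H]2[C@](C)(COC(=O)/C=C/c3ccccc3)[C@H](O)CC[C@@]2(C)[C@@H]1/C=C/C1=CCOC1=O`: 183000 nM
- Compound 2 `C=C1CC[C@@H]2[C@](C)(COC(=O)/C=C/c3cccc(OC)c3)[C@H](O)CC[C@@]2(C)[C@@H]1/C=C/C1=CCOC1=O`: > 1970000 nM
- Compound 3 `C=C1CC[C@@H]2[C@](C)(COC(=O)/C=C/c3cccc(Cl)c3)[C@H](O)CC[C@@]2(C)[C@@H]1/C=C/C1=CCOC1=O`: 147000 nM

These values come from an ADME assay on HepG2 2.2.15 cells (Homo sapiens) for cytotoxicity, read by MTT assay; a higher number here means that more compound is tolerated, a lower number that less compound is tolerated. Compound 2 is the best tolerated of the three, and its > 1970000 nM is a limit, not a number.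

Compound 4 `C=C1CC[C@@H]2[C@](C)(COC(=O)c3cccs3)[C@H](O)CC[C@@]2(C)[C@@H]1/C=C/C1=CCOC1=O` keeps the shared core but carries thiophen-2-yl in place of 2-(3-methoxyphenyl)ethenyl on a carbonyl carbon.

Within the data shown here, no measured step makes this exact change, but three bear on it. Adding the methoxy gave an at least 10-fold higher number from compound 1 to compound 2 (1.03 log units; beyond the scatter), a large step. Replacing it with chloro gave an at least 13-fold lower number from compound 2 to compound 3 (1.12 log units; beyond the scatter), also large. Chloro in place of hydrogen gave a 1.2-fold lower number from compound 1 to compound 3 (0.10 log units; within the scatter), within the scatter.

Compound 4 has no methoxy, so it is expected to land near compound 1 at 183000 nM and compound 3 at 147000 nM. Among the measured compounds shown here, the whole ethenyl group leaves as well, which no measured step covers, so the range is wide.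

The expected change is an at least 8.9-fold lower number from compound 2 to compound 4 (0.95 log units; beyond the scatter).

The estimate for compound 4 is 220000 nM, with an expected range from 70000 nM to 900000 nM.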

Compound 4, half-maximal cytotoxic concentration: 557000 nM
Estimate against measurement, compound 4: 2.5-fold (0.40 log units) below, within the range that was stated.
By their numbers in this assay, from the lowest: compounds 3 and 1 (each within the scatter of the next); then compound 4. At a limit, above all of these: compound 2.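

In this assay, the full exchange on this carbonyl carbon does not simply fall back to the level of the compounds without methoxy: thiophen-2-yl in place of 2-phenylethenyl gives a 3.0-fold higher number from compound 1 to compound 4 (0.48 log units; beyond the scatter), and in place of 2-(3-chlorophenyl)ethenyl it gives a 3.8-fold higher number from compound 3 to compound 4 (0.58 log units; beyond the scatter). So a methoxy group is not the only change at this position that moves the number upward, although replacing 2-(3-methoxyphenyl)ethenyl still gives an at least 3.5-fold lower number from compound 2 to compound 4 (0.54 log units; beyond the scatter). The value of compound 2 is a limit, so that last step has no upper end: the limit of > 1970000 nM in this assay, at which 1 of the 4 values shown sits.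

The compounds shown leave open whether the higher number comes from the thiophen-2-yl ring or from the missing ethenyl link, which a phenyl group set directly on the carbonyl carbon could help separate. Going by these compounds, how a methoxy or an amine on the thiophen-2-yl ring would read also remains open.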